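Chloro to fluoro on the anilino ring: compound 3 to compound 4

The source may hold more compounds than are shown below. What is called first, only, known or untested is meant among the compounds shown, and "the series" means these compounds.

Compound 1 `C=CC(=O)Nc1cccc(NC(=O)CSc2nc(Nc3ccccc3)c3ccccc3n2)c1` gives 8120 nM in a functional assay on NCI-H1975 cells (Homo sapiens) for inhibition, read by MTT assay, with a stated time of 72 h; on this read-out lower numbers stand for stronger inhibition and higher numbers for weaker inhibition.
Compound 2 `C=CC(=O)Nc1cccc(NC(=O)CSc2nc(Nc3ccccc3Br)c3ccccc3n2)c1` gives 19300 nM in this assay.
Compound 3 `C=CC(=O)Nc1cccc(NC(=O)CSc2nc(Nc3cccc(Cl)c3)c3ccccc3n2)c1` gives 9460 nM in this assay.

Compound 3 sits second highest of the three numbers. Its nearest neighbour is compound 1, since a 1.2-fold higher number from compound 1 to compound 3 (0.07 log units; within the scatter) stays within the scatter, and its furthest is compound 2, since a 2.0-fold lower number from compound 2 to compound 3 (0.31 log units; beyond the scatter) lies beyond it. Compound 4 `C=CC(=O)Nc1cccc(NC(=O)CSc2nc(Nc3ccc(F)cc3)c3ccccc3n2)c1` has not yet been measured; its difference from compound 3 is 4-fluorophenyl in place of 3-chlorophenyl on a nitrogen on an aromatic ring.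

Going by the values given here, three measured steps bear on this change, all of them swaps of a halogen on the same phenyl ring. Adding bromo gave a 2.4-fold higher number from compound 1 to compound 2 (0.38 log units; beyond the scatter), a modest worsening. Adding chloro gave a 1.2-fold higher number from compound 1 to compound 3 (0.07 log units; within the scatter), no real change. Exchanging one halophenyl for another gave a 2.0-fold lower number from compound 2 to compound 3 (0.31 log units; beyond the scatter), a modest improvement. Halogen changes on this ring have therefore moved this assay by small amounts only, and nothing suggests a larger shift for fluoro. The step of a 1.1-fold lower number from compound 3 to compound 4 (0.05 log units; within the scatter) is expected to stay close to the scatter, if anything toward a lower number. Compound 4 is thus estimated at 8500 nM, with a range from 4000 nM to 18000 nM.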

Compound 4, half-maximal inhibitory concentration: 4430 nM
Compound 4: the middle estimate sits 1.9-fold (0.28 log units) above what was measured; the range from low to high includes it.
By their numbers in this assay, from the lowest: compounds 4, 1 and 3 (each within the scatter of the next, the first and the last beyond it); then compound 2.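

In this assay, 4-fluorophenyl in place of 3-chlorophenyl on the nitrogen gives a 2.1-fold lower number from compound 3 to compound 4 (0.33 log units; beyond the scatter) and so shows that a change of halogen on this ring can move the number beyond the scatter, which adding chloro to the plain phenyl ring of compound 1 did not do. The range across this position also widens, with a 4.4-fold lower number from compound 2 to compound 4 (0.64 log units; beyond the scatter) as the largest gap among the four compounds, yet a 1.8-fold lower number from compound 1 to compound 4 (0.26 log units; within the scatter) stays within the scatter, so compound 4 cannot be ranked ahead of compound 1 and fluoro cannot be said to improve on hydrogen here. No supporting measurement is available to explain any of these differences.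

Compound 3 and compound 4 differ in both the halogen and its place on the ring, so these data cannot separate the two effects, and 3-fluorophenyl and 4-chlorophenyl groups would be the direct comparisons. As far as these compounds go, how a methoxy group or an amine on this ring would behave also remains open.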